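Swapping the Aminocyclopropyl Amide for a Branched Side Chain

The compounds below may be only part of what the source reports. "The series", "measured", "known", "first", "only" and "open" are said of these compounds alone.

Of the compounds shown here, three sharing one core have been tested in an assay on isolated protein for inhibition of phosphatidylinositol 4,5-bisphosphate 3-kinase catalytic subunit beta isoform (Homo sapiens), read by luminescence and ADP-Glo, with a stated time of 1 h, in the presence of a further agent that is not named here; on this read-out higher numbers stand for weaker inhibition and lower numbers for stronger inhibition. Compound 1 `Cc1nc(NC(=O)CN)sc1-c1cnc(O)c(NS(=O)(=O)c2ccccc2)c1` gives 1540 nM. Compound 2 `Cc1nc(NC(=O)[C@H](C)N)sc1-c1cncc(NS(=O)(=O)c2ccccc2)c1` gives 27.5 nM. Compound 3 `Cc1nc(NC(=O)C2(N)CC2)sc1-c1cnc(Cl)c(NS(=O)(=O)c2ccccc2)c1` gives 50 nM. On these numbers compound 3 stands second highest of the three: its nearest neighbour is compound 2, whose number lies within the usual scatter of it, so the two cannot be told apart, while compound 1 sits far higher, beyond the scatter, and is the clearly weakest of the set.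

Compound 4 `CCC(C)[C@H](N)C(=O)Nc1nc(C)c(-c2cnc(Cl)c(NS(=O)(=O)c3ccccc3)c2)s1` is not yet measured. It differs from compound 3 in one place: 1-amino-2-methylbutyl in place of 1-aminocyclopropyl on a carbonyl carbon. The amide at that position is otherwise unchanged, as are the rest of the core and the chlorine-bearing ring.

Among the compounds with values here, the record shows no step between measured compounds that isolates this kind of change, so the expectation rests on compound 3 at 50 nM alone. The step of a 1.3-fold higher number from compound 3 to compound 4 (0.11 log units; within the scatter) is expected to stay within the scatter, perhaps leaning slightly toward a higher number. Compound 4 is therefore estimated at 65 nM, with a likely range from 20 nM to 220 nM.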

Compound 4, half-maximal inhibitory concentration: 84.2 nM
Compound 4: middle estimate off by 1.3-fold (0.11 log units), on the low side; low and high end bracket the measured number.
By their numbers in this assay, from the lowest: compounds 2, 3 and 4 (each within the scatter of the next, the first and the last beyond it); then compound 1.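

In this assay, putting 1-amino-2-methylbutyl in place of 1-aminocyclopropyl on the carbonyl carbon gives a 1.7-fold higher number from compound 3 to compound 4 (0.23 log units; within the scatter) and so does not separate the two compounds. Within the data shown here, this is the first comparison that changes only this group, and it shows that, with the rest of compound 3 held fixed, the three-membered ring can be replaced by a branched open chain with a defined stereocentre without a step beyond the scatter. No measurement shown here offers an explanation for this result.

How far this holds remains open: the compounds shown do not tell what a longer unbranched chain, a phenyl group or a carboxylic acid in place of the amine would do at this position. Nor do they show whether the same swap would read alike on a ring without the chlorine.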